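Para-chloro on the anilide-side aniline of a diarylpyridine amide

The source may hold more compounds than are shown below. What is called first, only, known or untested is meant among the compounds shown, and "the series" means these compounds.

Measured compounds:
compound 1, `O=C(Nc1ccccc1)c1c(-c2ccc(Cl)cc2)cc(-c2ccccc2)nc1N1CCCCC1`, 13%
compound 2, `O=C(Nc1ccccc1)c1c(-c2ccc(Cl)cc2)cc(-c2ccccc2)nc1Nc1ccccc1`, 15%

In a functional assay on RPMI18226 cells (Homo sapiens) for antiproliferative activity, read by sulforhodamine B assay, with a stated time of 48 h, tested at 10 uM (on this read-out higher numbers stand for more inhibition at the one concentration tested (going by the name of the read-out) and lower numbers for less inhibition), compound 1 gives 13% and compound 2 gives 15%. Compound 2 thus stands at the higher of the two numbers, yet the step of a number 2 percentage points higher from compound 1 to compound 2 (within the scatter) lies within the scatter, so the two compounds cannot be told apart on this read-out. Compound 3, `O=C(Nc1ccccc1)c1c(-c2ccc(Cl)cc2)cc(-c2ccccc2)nc1Nc1ccc(Cl)cc1`, differs from compound 2 by chloro in place of hydrogen on an aromatic carbon. Among the compounds with values here, no measured step touches this ring: the only step available, a number 2 percentage points higher from compound 1 to compound 2 (within the scatter), concerns a different site and was itself within the scatter. With both measured numbers low and close together, the account expects no change beyond the scatter for compound 3, and the estimated step of a number 3 percentage points higher from compound 2 to compound 3 (within the scatter) is put at a size that stays inside it. The estimate for compound 3 in this assay is therefore 18%, within a range from 5% to 35%.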

Compound 3, a percentage reported as inhibition, at one concentration (the size of the read-out at that concentration, not a potency): 53%
For compound 3 the middle estimate is 35 percentage points below the measured one, outside the stated range (above it).
By their numbers in this assay, from the lowest: compounds 1 and 2 (each within the scatter of the next); then compound 3.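

In this assay the anilino ring proves responsive to substitution: chloro in place of hydrogen, para to a large group, gives a number 38 percentage points higher from compound 2 to compound 3 (beyond the scatter), a large step, whereas the earlier exchange of piperidin-1-yl for anilino stayed within the scatter. Exchanging piperidin-1-yl for (4-chlorophenyl)amino gives a number 40 percentage points higher from compound 1 to compound 3 (beyond the scatter), so the change is large only when the chloro is present on the anilino ring. Nothing available explains why this single atom has such an effect.

On these data alone, whether the gain is particular to chloro, or would also follow from fluoro, bromo, methoxy or a carboxylic acid in the same place, remains open. Also open, as far as these compounds go, is whether chloro elsewhere on this ring would give a comparable step, and what potency lies behind a reading at one concentration.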